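Anilino to fused bicyclic amine on a benzoxazole-type core

The compounds below may be only part of what the source reports. "The series", "measured", "known", "first", "only" and "open" are said of these compounds alone.

Measured so far:
compound 1, `c1cc2cc(-c3ccc4oc(NC5CCCCC5)nc4c3)cnc2[nH]1`: > 1000 nM
compound 2, `Cn1ncc2cc(-c3ccc4oc(NC5CCCCC5)nc4c3)ccc21`: 61 nM
compound 3, `Cn1ccc2cc(-c3ccc4oc(Nc5ccccc5)nc4c3)ccc21`: 48 nM

Of the compounds shown here, three have been tested in an assay on HEK293 cells for inhibition of Fatty-acid amide hydrolase 1 (Homo sapiens), read by fluorescence; on this read-out lower numbers stand for stronger inhibition and higher numbers for weaker inhibition. Compound 1 `c1cc2cc(-c3ccc4oc(NC5CCCCC5)nc4c3)cnc2[nH]1` gives only a limit of the assay, > 1000 nM, and (the limit of > 1000 nM in this assay, at which 1 of the 3 values shown sits). Compound 2 `Cn1ncc2cc(-c3ccc4oc(NC5CCCCC5)nc4c3)ccc21` gives 61 nM. Compound 3 `Cn1ccc2cc(-c3ccc4oc(Nc5ccccc5)nc4c3)ccc21` gives 48 nM, the lowest of the two numbers shown; its gap to compound 2 is within the usual scatter, so no order between these two can be claimed.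

The next compound, compound 4 `Cn1ccc2cc(-c3ccc4oc(N5Cc6cccnc6C5)nc4c3)ccc21`, has not yet been measured in this assay. Compared with compound 3 it carries a different group on an aromatic carbon of the five-membered aromatic ring with one nitrogen and one oxygen: a group of 9 heavy atoms (7 carbon, 2 nitrogen; one five-membered non-aromatic ring with 1 hetero atom, one six-membered aromatic ring with 1 hetero atom) in place of a group of 7 heavy atoms (6 carbon, 1 nitrogen; one six-membered aromatic ring of carbon only), on an aromatic carbon. The anilino group with its single hydrogen-bond donor leaves, and a larger group without a donor enters.

Within the data shown here, no measured step among the three compounds shows what such a change does here. The account therefore expects a modest weakening, a 3.1-fold higher number from compound 3 to compound 4 (0.49 log units; beyond the scatter), beyond the scatter but not by much. Compound 4 is estimated at 150 nM, with a range from 40 nM to 600 nM.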

Compound 4, half-maximal inhibitory concentration: 211 nM
For compound 4 the middle estimate is 1.4-fold (0.15 log units) below the measured one; the measured number falls inside the stated range.
By their numbers in this assay, from the lowest: compounds 3 and 2 (each within the scatter of the next); then compound 4. At a limit, above all of these: compound 1.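

In this assay, the step at this position, the aromatic carbon of the five-membered aromatic ring with 1 nitrogen and 1 oxygen, is a 4.4-fold higher number from compound 3 to compound 4 (0.64 log units; beyond the scatter) and so is modest. The anilino group can therefore give way to a group of 9 heavy atoms, with one five-membered non-aromatic ring and one six-membered aromatic ring with 1 hetero atom, at a modest cost, and compound 4 still gives a number, 211 nM in this assay. The hydrogen-bond donor leaves and the group grows in the same step, so the result cannot assign the change to either one, and no measured property bears on why the number rises.

The compounds shown leave open whether a methylanilino group, which would remove the donor while keeping the benzene ring, would behave like the anilino group of compound 3 or like the group of compound 4. They also leave open how a simple saturated amine such as pyrrolidine or morpholine would fare at this position on the same core.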